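Fluorine in place of phenyl at the far end of compound 1

The source may report more compounds than this note shows. Statements on the series, on what has been measured and on what is new or still open speak of the compounds shown alone.

Compound 1, `CC(C)[C@H](NC(=O)COc1cccc2ccccc12)C(=O)N[C@@H](CC(=O)O)C(=O)COc1ccc(-c2ccccc2)cc1`, gives 87900 nM in a functional assay on Jurkat cells (Homo sapiens); a lower number here means a stronger inhibitor, a higher number a weaker inhibitor.
Compound 2, `CC(C)[C@H](NC(=O)COc1cccc2ccccc12)C(=O)N[C@@H](CC(=O)O)C(=O)COc1ccc(C#N)cc1`, gives > 100000 nM in this assay, which is a limit of the assay and not a number.
Compound 3, `CC(=O)Nc1cccc(OCC(=O)[C@H](CC(=O)O)NC(=O)[C@@H](NC(=O)COc2cccc3ccccc23)C(C)C)c1`, gives > 100000 nM in this assay, which is also a limit and not a number.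

Among these three, compound 1 is the only one with a number; the other two sit at the limit of > 100000 nM in this assay, at which 2 of the 3 values shown sit. Compound 4, `CC(C)[C@H](NC(=O)COc1cccc2ccccc12)C(=O)N[C@@H](CC(=O)O)C(=O)COc1ccc(F)cc1`, has not yet been measured. It differs from compound 1 in one place: fluoro in place of phenyl on an aromatic carbon.

Going by the values given here, two measured steps bear on this change. The closest is an at least 1.1-fold higher number from compound 1 to compound 2 (0.05 log units; that floor lies within the scatter), where a small group replaced the same phenyl at the same place and the result reached the limit. The other is an at least 1.1-fold higher number from compound 1 to compound 3 (0.05 log units; that floor lies within the scatter), where the whole outer ring was exchanged and the result again reached the limit. From the compounds shown here alone, both point the same way, toward weaker inhibition, though their true sizes are unknown.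

Compound 4 is therefore expected to inhibit more weakly than compound 1, with a fair chance of landing at the limit itself. The estimate for compound 4 in this assay is 130000 nM, with a range from 40000 nM to 400000 nM. This means an expected step of a 1.5-fold higher number from compound 1 to compound 4 (0.17 log units; within the scatter).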

Compound 4, half-maximal inhibitory concentration: > 100000 nM
Compound 4 was reported as a limit; the forecaster's own chance of this, stated with the estimate: 60%; the middle value lies beyond the limit too.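

Replacing phenyl with a single fluorine atom on the aromatic carbon gives an at least 1.1-fold higher number from compound 1 to compound 4 (0.05 log units; that floor lies within the scatter) in this assay, and the value of compound 4 is a limit of the assay, not a number. Going by these compounds alone, that makes fluoro the third replacement for the outer ring to give no number, leaving the 4-phenylphenyl of compound 1 as the only outer group here with a measured value, while the others gather at one limit: the limit of > 100000 nM in this assay, at which 3 of the 4 values shown sit. The floor of the step lies within the scatter, so a real loss from phenyl to fluoro is not established, and the steps among compound 2, compound 3 and compound 4 cannot be read, which leaves fluoro, nitrile and 3-acetamidophenyl unranked.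

From the compounds shown here alone, whether a smaller replacement such as an amine or a methoxy group would give a number in this assay remains open. Also open, going by these compounds, is whether a larger outer group than 4-phenylphenyl, such as a benzyl group on the same ring or a longer chain ending in a phenyl ring, would give stronger inhibition than compound 1, which gives 87900 nM.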